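The source may report more compounds than this note shows. Statements on the series, on what has been measured and on what is new or still open speak of the compounds shown alone.

Compound 2 `COc1cccc(-n2cc3nc(-c4cccnc4C)n(C[C@H]4CCCN(CC5CCCCO5)C4)c(=O)c3n2)c1` is the weakest of the three compounds measured in an assay on HEK293 cells for displacement of a labelled ligand from growth hormone secretagogue receptor type 1 (Homo sapiens), with a stated time of 60 min; on this read-out higher numbers stand for weaker inhibition and lower numbers for stronger inhibition: compound 2 gives 120 nM, whereas compound 1 `COc1cccc(-n2cc3nc(-c4cccnc4C)n(C[C@H]4CCCN(CC5CCO5)C4)c(=O)c3n2)c1` gives 23 nM and compound 3 `COc1ccc(-n2cc3nc(-c4ccccc4C)n(CC4CCCN(C(C)C)C4)c(=O)c3n2)cc1` gives 7.3 nM. Compound 4 `COc1cccc(-n2cc3nc(-c4cccnc4C)n(C[C@H]4CCCN(CC5CCCC5)C4)c(=O)c3n2)c1` differs from compound 2 in a single place: cyclopentyl in place of oxan-2-yl on a saturated chain carbon bound to an amine nitrogen in a ring.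

Among the measured compounds shown here, only one measured step touches this part of the molecule, a 5.2-fold higher number from compound 1 to compound 2 (0.72 log units; beyond the scatter), which exchanged one oxygen-containing ring for another on the same saturated chain carbon bound to the amine nitrogen. For the measured compounds named here, no measured pair shows what happens when the ring on that carbon carries no oxygen at all, so the guidance is thin. Going by the values given here, the step to compound 4 also changes the ring size, and the one measured ring-size step moved the number upward by a modest amount, so some movement back toward the value of compound 1 is plausible, but a step that stays within the scatter cannot be ruled out. Compound 4 is therefore expected to come out at about 75 nM, within a range of 30 nM to 250 nM, which would mean an expected step of a 1.6-fold lower number from compound 2 to compound 4 (0.20 log units; within the scatter).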

Compound 4, half-maximal inhibitory concentration: 12 nM
Estimate against measurement, compound 4: 6.3-fold (0.80 log units) above; the whole stated range lies above it.
By their numbers in this assay, from the lowest: compounds 3, 4 and 1 (each within the scatter of the next, the first and the last beyond it); then compound 2.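

Replacing oxan-2-yl with cyclopentyl in this assay gives a 10-fold lower number from compound 2 to compound 4 (1.00 log units; beyond the scatter), so this position accepts a ring of carbon only and needs no ring oxygen for a low number. Replacing oxetan-2-yl with the same group gives a 1.9-fold lower number from compound 1 to compound 4 (0.28 log units; within the scatter), which leaves compound 1, with a ring oxygen, and compound 4, without one, indistinguishable and sets the oxan-2-yl ring of compound 2 apart from both. Nothing available here explains why that ring gives the higher number.

From the compounds shown here alone, it remains open whether cyclohexyl, a six-membered ring of carbon only, would read like oxan-2-yl or like cyclopentyl, which would help separate the effect of ring size from that of the ring oxygen. How an open carbon chain or a piperidine ring would behave at this place is also an open question.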